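Acetyl to dimethylamino on the para aryl: cytotoxicity note

This account rests on a few compounds, and the source may have more. Where it says the series, first, only, none or still open, it means among the compounds named here.

Measured so far:
compound 1, `COc1cc(C)cc(-c2c(-c3ccnc(-c4ccc(C(C)=O)cc4)c3)cnn2CC#N)c1`: 110%
compound 2, `Cc1cc(O)cc(-c2nn(CC#N)cc2-c2ccnc(-c3ccc(N(C)C)cc3)c2)c1`: 101%

Two compounds of this series carry a number in a functional assay on HT-29 cells (Homo sapiens) for cytotoxicity, read by sulforhodamine B assay, with a stated time of 48 h, tested at 0.001 uM; on this read-out higher numbers stand for a weaker effect at the one concentration tested and lower numbers for a stronger effect. Compound 1 gives 110%, and compound 2 gives 101%; the two numbers lie within the usual scatter of each other, so neither can be set apart from the other. Both read as little or no effect at the single concentration tested.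

Compound 3 is `COc1cc(C)cc(-c2c(-c3ccnc(-c4ccc(N(C)C)cc4)c3)cnn2CC#N)c1`, not yet measured. Relative to compound 1 the difference is dimethylamino in place of acetyl on an aromatic carbon. Among the measured compounds shown here, no pair of measured compounds differs in this one place, so no measured step speaks to the change directly. Compound 2 does carry the dimethylamino group that enters, and its value is indistinguishable from that of compound 1, but the two structures differ elsewhere as well.

For compound 3 the expected step of a number 6 percentage points lower from compound 1 to compound 3 (within the scatter) is therefore none beyond the scatter, in either direction. The estimate for compound 3 in this assay is 104%, with a range from 90% to 117%.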

Compound 3, a percentage reported as activity, at one concentration (the size of the read-out at that concentration, not a potency): 94%
Beside the measured number, compound 3's estimate is 10 percentage points above it, and the stated range covers the measured number.
By their numbers in this assay, from the lowest: compounds 3, 2 and 1 (each within the scatter of the next, the first and the last beyond it).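

The swap of acetyl for dimethylamino on an aromatic carbon, para to a large group, now has a direct reading in this assay: the change gives a number 16 percentage points lower from compound 1 to compound 3 (beyond the scatter), a modest step that compound 1 and compound 2 could not provide, since their structures differ in more than one place. This position therefore responds to the identity of the group, even though the two groups match in heavy-atom count, each with one hydrogen-bond acceptor, no donors and no net charge, so those counts do not separate them. The reading comes from a single pair at one concentration and is not a potency, and nothing available accounts for the step.

On these data alone, whether a primary amine, a methoxy group or a carboxylic acid at the same place would move the number further, or in the opposite direction, remains open. Also open, as far as these compounds go, is whether the same swap gives a similar step on the core of compound 2, which carries a hydroxyl group on its other aryl ring, and whether the step persists at higher concentrations.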